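Fluoro for trifluoromethyl, para then ortho

This account rests on a few compounds, and the source may have more. Where it says the series, first, only, none or still open, it means among the compounds named here.

Compound 1 `CC1=C(/C=C/C(=O)/C=C/c2ccc(C(F)(F)F)cc2)C(C)(C)CCC1` and compound 2 `CC1=C(/C=C/C(=O)/C=C/c2ccc(F)cc2)C(C)(C)CCC1` share one core. In a functional assay on PC-3 cells (Homo sapiens) for cytotoxicity, read by MTT assay, with a stated time of 72 h (a higher number here means a weaker inhibitor, a lower number a stronger inhibitor), compound 1 gives 12000 nM, and compound 2 gives 25800 nM. The change fluoro in place of trifluoromethyl on an aromatic carbon made a step of a 2.2-fold higher number from compound 1 to compound 2 (0.33 log units; beyond the scatter). Compound 3 `CC1=C(/C=C/C(=O)/C=C/c2ccccc2C(F)(F)F)C(C)(C)CCC1O` stands on a different core; the difference between the two cores is not broken down here. In this assay compound 3 gives 3700 nM, the lowest of the three numbers. Compound 4 `CC1=C(/C=C/C(=O)/C=C/c2ccccc2F)C(C)(C)CCC1O` takes the same kind of change from compound 3, (fluoro in place of trifluoromethyl on an aromatic carbon); the place is ortho to a large group here, against para to a large group in compound 2. Because the same kind of change gave a 2.2-fold higher number from compound 1 to compound 2 (0.33 log units; beyond the scatter), compound 4 is expected to give 8000 nM. For compound 4 the expected range runs from 4000 nM to 16000 nM. The step this estimate means is expected to be a 2.2-fold higher number from compound 3 to compound 4 (0.33 log units; beyond the scatter).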

Compound 4, half-maximal inhibitory concentration: 10400 nM
Estimate against measurement, compound 4: 1.3-fold (0.11 log units) below, within the range that was stated.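

In this assay fluoro in place of trifluoromethyl on an aromatic carbon made a 2.8-fold higher number from compound 3 to compound 4 (0.45 log units; beyond the scatter), and the change ran in the same direction on both cores, with steps of similar size: the same change on two cores in this assay, a 2.2-fold higher number (0.33 log units; beyond the scatter) from compound 1 to compound 2 and a 2.8-fold higher number (0.45 log units; beyond the scatter) from compound 3 to compound 4, 1.3-fold (0.12 log units) apart, within the scatter of two such steps. This supports carrying the change between the core of compound 1 and the core of compound 3 in this assay. For the compounds shown here, it rests on only two pairs, which differ in place as well as in core, and so does not show that the step is independent of either or that it would hold on other cores.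

The compounds shown leave open how an amine or a methoxy group on the same aromatic carbon would compare with fluoro and trifluoromethyl. They also leave open how each of these groups would behave at one fixed place on both cores.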